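Compound 4: a methyl group where compound 3 has chloro

The source may report more compounds than this note shows. Statements on the series, on what has been measured and on what is new or still open speak of the compounds shown alone.

Compound 1 `Cc1ccc(OP(=O)(O)OC[C@H]2O[C@@H](n3cc(C)c(=O)[nH]c3=O)C[C@@H]2N=[N+]=[N-])cn1` gives 28.9 h
Compound 2 `Cc1cn([C@H]2C[C@H](N=[N+]=[N-])[C@@H](COP(=O)(O)Oc3cccnc3)O2)c(=O)[nH]c1=O` gives 3.88 h
Compound 3 `Cc1cn([C@H]2C[C@H](N=[N+]=[N-])[C@@H](COP(=O)(O)Oc3cncc(Cl)c3)O2)c(=O)[nH]c1=O` gives 7.27 h

These numbers come from a physicochemical assay for metabolic stability, read by HPLC (a lower number here means that the compound disappears faster, a higher number that the compound lasts longer), and the three compounds share one core. Compound 3 sits low among them. The data show a 4.0-fold lower number from compound 1 to compound 3 (0.60 log units; beyond the scatter) and also a 1.9-fold higher number from compound 2 to compound 3 (0.27 log units; within the scatter) so the two lower numbers cannot be told apart.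

Compound 4 `Cc1ncccc1OP(=O)(O)OC[C@H]1O[C@@H](n2cc(C)c(=O)[nH]c2=O)C[C@@H]1N=[N+]=[N-]` comes next, and 2-methylpyridin-3-yl in place of 5-chloropyridin-3-yl on an oxygen sums up the change: 2-methylpyridin-3-yl in place of 5-chloropyridin-3-yl on an oxygen.

For the measured compounds named here, two measured steps bear on this. Losing the chloro should matter little, since the only chloro comparison stayed within the scatter. Gaining a methyl is the larger question: the one methyl comparison is a 7.4-fold lower number from compound 1 to compound 2 (0.87 log units; beyond the scatter) and there the methyl was lost. Compound 1 carries its methyl at a different place on the ring from compound 4, so that step may carry over only in part. Going by the values given here, no measured compound has a methyl where compound 4 has it.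

The expected change in this assay is a modest rise, with a 2.2-fold higher number from compound 3 to compound 4 (0.34 log units; beyond the scatter) as the estimated step. The estimate for compound 4 is 16 h with an expected range from 5 h to 50 h as its limits.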

Compound 4, half-life: 15.8 h
The estimate for compound 4 lay 1.0-fold (0.01 log units) above the measured number; the measured number falls inside the stated range.
By their numbers in this assay, from the lowest: compounds 2 and 3 (each within the scatter of the next); then compounds 4 and 1 (each within the scatter of the next).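

In this assay, the new compound gives the methyl group a second place on the pyridine ring, and it again goes with a longer-lasting compound: a 4.1-fold higher number from compound 2 to compound 4 (0.61 log units; beyond the scatter) is the step for adding methyl to the plain pyridin-3-yl group, and a 2.2-fold higher number from compound 3 to compound 4 (0.34 log units; beyond the scatter) is the step for replacing 5-chloropyridin-3-yl with 2-methylpyridin-3-yl. Until now, only the 6-methylpyridin-3-yl group of compound 1 had shown such a gain, yet a 1.8-fold lower number from compound 1 to compound 4 (0.26 log units; within the scatter) means that the two methyl-bearing groups cannot be told apart. Among these four compounds, then, both with a methyl group lie above both without one, none goes against this, and the exact place of the methyl shows no measurable effect in this pair. Nothing shown here gives a measured reason for these differences.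

Still open, as far as these compounds go, is whether the gain belongs to methyl alone, or whether an ethyl group, a methoxy group or an amine in its place on 2-methylpyridin-3-yl would give a similar number. Also open, from the compounds shown here alone, is how a single pyridine ring carrying both chloro and methyl would behave in this assay when attached to the oxygen on phosphorus.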